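The source may hold more compounds than are shown below. What is called first, only, known or untested is meant among the compounds shown, and "the series" means these compounds.

Measured so far:
- compound 1 `Cc1ccc(NC(=O)C(=O)Nc2ccc(OCC(=O)O)c(F)c2)cc1`: 11.4%
- compound 2 `O=C(O)COc1ccc(NC(=O)c2ccccc2)cc1F`: 3.56%

In a functional assay on CHO cells for agonist activity at Free fatty acid receptor 1 (Homo sapiens), read by FLIPR, tested at 100 nM (on this read-out lower numbers stand for a weaker effect and higher numbers for a stronger effect at the one concentration tested), compound 2 gives 3.56%, the lowest of the two numbers; compound 1 gives 11.4%, a gap that lies within the scatter. Compound 3 `O=C(O)COc1ccc(NC(=O)Nc2ccccc2)cc1F` is not yet measured. It differs from compound 2 by anilino in place of phenyl on a carbonyl carbon. Among the compounds with values here, no step between measured compounds is available here, so the expectation rests on the values of compound 2 and compound 1 alone. With both measured values sitting low, no step beyond the scatter is expected for a number 2.4 percentage points higher from compound 2 to compound 3 (within the scatter). For compound 3 the expected value in this assay is 6%, with a range from 0% to 18%.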

Compound 3, a percentage reported as activity, at one concentration (the size of the read-out at that concentration, not a potency): 8.47%
The estimate for compound 3 lay 2.5 percentage points below the measured number, within the range that was stated.
By their numbers in this assay, from the lowest: compounds 2, 3 and 1 (each within the scatter of the next).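

At this carbonyl carbon, anilino in place of phenyl adds one nitrogen and one hydrogen-bond donor and gives a number 4.9 percentage points higher from compound 2 to compound 3 (within the scatter) in this assay. Within the data shown here, this is the first one-place step, and at the single concentration tested it does not separate the two compounds. Nothing measured here bears on a cause for this step.

Still open, from the compounds shown here alone, is whether benzylamino on the same carbonyl carbon, or a methyl or chlorine on the anilino ring, would move the number beyond the scatter.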